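The source may hold more compounds than are shown below. What is called first, only, known or untested is meant among the compounds shown, and "the series" means these compounds.

In a physicochemical assay for lipophilicity, read by HPLC, using the shake flask method, measured as octanol-water partition, with a stated time of 24 h, at pH 7.4 (on this read-out lower numbers stand for lower lipophilicity and higher numbers for higher lipophilicity), compound 1 (`COC(=O)Cn1c(=O)oc2c(C(=O)/C=C/c3cc(F)c(O)c(F)c3)cccc21`) gives 1.07 and compound 2 (`CC(C)=CCn1c(=O)oc2c(C(=O)/C=C/c3ccc(O)c(F)c3)cccc21`) gives 1.64. Compound 2 thus holds the higher of the two numbers, and the gap between them lies beyond the scatter. Compound 3 (`CC(C)=CCn1c(=O)oc2c(C(=O)/C=C/c3cc(F)c(O)c(F)c3)cccc21`) differs from compound 2 in one place: fluoro in place of hydrogen on an aromatic carbon. This puts fluoro in place of hydrogen on an aromatic carbon, ortho to a hydroxy group, so that 3-fluoro-4-hydroxyphenyl becomes 3,5-difluoro-4-hydroxyphenyl. For the measured compounds named here, no measured pair here shows this change alone. Compound 1, at 1.07, already carries the 3,5-difluoro-4-hydroxyphenyl group, but it also differs from compound 2 elsewhere, so its number cannot size the step. A small change in this assay, not beyond the scatter, is therefore expected. The estimated step is a number 0.09 log units lower from compound 2 to compound 3 (within the scatter). For compound 3 the estimated value is 1.55, with an expected range of 1.05 to 2.05.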

Compound 3, distribution coefficient: 1.13
Compound 3: the middle estimate sits 0.42 log units above what was measured, within the range that was stated.
By their numbers in this assay, from the lowest: compounds 1 and 3 (each within the scatter of the next); then compound 2.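

In this assay, fluoro in place of hydrogen on an aromatic carbon, ortho to a hydroxy group, can now be read alone: 3-fluoro-4-hydroxyphenyl to 3,5-difluoro-4-hydroxyphenyl gives a number 0.51 log units lower from compound 2 to compound 3 (beyond the scatter). With that difluoro group held fixed, 2-methylprop-1-en-1-yl in place of methoxycarbonyl on a saturated chain carbon bound to an aromatic nitrogen gives a number 0.06 log units higher from compound 1 to compound 3 (within the scatter), so this change separates the two compounds by no more than the scatter. Nothing measured here accounts for the size of either step. The compounds shown leave open whether the fluoro step keeps its size when a carboxylic acid or an amine stands on that chain. They also leave open whether chloro in place of the added fluoro would give a similar step.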